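The source may report more compounds than this note shows. Statements on the series, on what has been measured and on what is new or still open speak of the compounds shown alone.

The compounds here share one core and differ in the group on the amide-type nitrogen. In an ADME assay on microsomes from liver (Mus musculus, strain CD-1) for metabolic stability, read by LC-MS, tested at 2 uM (a higher number here means that the compound lasts longer, a lower number that the compound disappears faster), compound 1 (`Cn1cc(NC(=O)c2ccncc2Nc2cc(-c3ccc4ccn(C)c4c3)c3nccnc3c2)cn1`) shows a half-life of 0.2 h and disappears fairly quickly. Compound 2 (`CN1CC(NC(=O)c2ccncc2Nc2cc(-c3ccc4ccn(C)c4c3)c3nccnc3c2)C1`) reads > 1 h in this assay and this is a limit of the assay, not a number. Compound 2 therefore stands at the limit of > 1 h in this assay, at which 1 of the 2 values shown sits, and gives no exact starting point. Swapping 1-methyl-1H-pyrazol-4-yl for 1-methylazetidin-3-yl gave an at least 5.0-fold higher number from compound 1 to compound 2 (0.69 log units; beyond the scatter) and this is the only measured step that bears on what follows.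

Compound 3 (`CC(=O)N1CC(CNC(=O)c2ccncc2Nc2cc(-c3ccc4ccn(C)c4c3)c3nccnc3c2)C1`) carries (1-acetylazetidin-3-yl)methyl in place of 1-methylazetidin-3-yl on the same amide-type nitrogen ((1-acetylazetidin-3-yl)methyl in place of 1-methylazetidin-3-yl on an amide-type nitrogen). The four-membered ring stays, and the 1-methyl-1H-pyrazol-4-yl group of compound 1 stays absent. Among the compounds with values here, compound 3 is thus expected to resemble compound 2 more than compound 1, though no measured step tests this exact change. The expected change is an at least 1.2-fold lower number from compound 2 to compound 3 (0.09 log units; that floor lies within the scatter) and it should be small, perhaps a slight fall. In this assay the estimated half-life of compound 3 is 0.8 h with an expected range from 0.3 h to 1.5 h.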

Compound 3, half-life: > 1 h
Compound 3 was reported as a limit; the forecaster's own chance of this, stated with the estimate: 40%; middle value at least 1.2-fold (0.09 log units) away from the limit.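

In this assay compound 3 reads > 1 h, and this is a limit of the assay, not a number. Placing (1-acetylazetidin-3-yl)methyl on the amide-type nitrogen gives an at least 5.0-fold higher number from compound 1 to compound 3 (0.69 log units; beyond the scatter), so the gain over the 1-methyl-1H-pyrazol-4-yl group does not rest on 1-methylazetidin-3-yl alone: two different groups that each carry a four-membered non-aromatic ring now show a step beyond the scatter at this position. The comparison between those two groups cannot be read, because compound 2 and compound 3 stand at the same limit: the limit of > 1 h in this assay, at which 2 of the 3 values shown sit.

From the compounds shown here alone, how much longer than the limit either compound lasts stays open, so the two groups cannot be ranked against each other. The compounds shown also do not tell whether the four-membered ring matters in itself, or whether a piperidine ring or an open-chain amine on the same amide-type nitrogen would give a similar half-life.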